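A few compounds are considered here, and "the series" means these few. Any claim that something is new, unique, unknown or untested is made for them only; others in the source may bear on it.

Of the compounds shown here, three built on a shared core have been measured in a functional assay on a cell-free system (plasma, Homo sapiens), with a stated time of 3 min; on this read-out lower numbers stand for stronger inhibition and higher numbers for weaker inhibition. Compound 1 `O=C(NCc1cc(Cl)ccc1-n1cnnn1)[C@@H]1[C@H]2C[C@H]2CN1C(=O)[C@H](O)c1ccccc1` gives 960 nM. Compound 2 `O=C(NCc1cc(Cl)ccc1-n1cnnn1)[C@@H]1[C@@H]2C[C@@H]2CN1C(=O)[C@H](O)c1ccccc1` gives 700 nM, and compound 3 `O=C(NCc1cc(Cl)ccc1-n1cnnn1)[C@@H]1C[C@@H]2C[C@@H]2N1C(=O)[C@H](O)c1ccccc1F` gives 770 nM. Compound 2 thus gives the smallest of the three numbers, but its gaps to compound 3 and to compound 1 are within the usual scatter, so none of the three can be called stronger than another. For the measured compounds named here, the only step between two compounds that differ in one place is a 1.4-fold lower number from compound 1 to compound 2 (0.14 log units; within the scatter); it rests on the fact that compounds 1 and 2 differ only in the configuration as drawn and shifts nothing beyond the scatter.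

Compound 4 `O=C(NCc1cc(Cl)ccc1-n1cnnn1)[C@@H]1[C@@H]2C[C@@H]2CN1C(=O)[C@H](O)Cc1ccccc1` has not yet been measured. It differs from compound 2 in a single place: benzyl in place of phenyl on a saturated chain carbon bound to a carbonyl carbon and an oxygen on a saturated carbon. Going by the values given here, no measured step touches this part of the molecule, since the one step available concerns configuration alone, so there is no direct guide to the size or direction of the move in this assay. Compound 4 is therefore expected to land near the numbers seen so far, with a wide range to allow for the untested change. The expected step is a 1.3-fold higher number from compound 2 to compound 4 (0.11 log units; within the scatter). For compound 4 the estimate is 900 nM, lying between 300 nM and 2700 nM.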

Compound 4, half-maximal inhibitory concentration: 970 nM
Estimate against measurement, compound 4: 1.1-fold (0.03 log units) below, and the stated range covers the measured number.
By their numbers in this assay, from the lowest: compounds 2, 3, 1 and 4 (each within the scatter of the next).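

Compound 4 gives the only view of this position, where the change gives a 1.4-fold higher number from compound 2 to compound 4 (0.14 log units; within the scatter) in this assay. Going from hydroxy(phenyl)methyl to 1-hydroxy-2-phenylethyl keeps the aromatic ring and the hydroxy group, so the ring stays in the molecule while the chain grows, and this read-out registers no shift beyond the scatter. The one fact on record about these compounds concerns configuration and does not bear on this phenyl-to-benzyl change, so nothing here explains why the step is so small.

One step at one position cannot show how much change this position accepts in general, and a longer chain such as 2-phenylethyl could behave differently from benzyl, as could an amine or a carboxylic acid in place of the aromatic ring. Going by these compounds, it also remains open whether benzyl would give a similar result on the core of compound 1 or on the core of compound 3, or with a fluorine on its ring, as the phenyl ring of compound 3 carries.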